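Second bromomethyl on the shared core: projecting compound 4

This account rests on a few compounds, and the source may have more. Where it says the series, first, only, none or still open, it means among the compounds named here.

Measured so far:
compound 1 `CC(C)OCC1=CS(=O)(=O)c2ccccc2C1=O` — 99.2%
compound 2 `O=C1C(CBr)=CS(=O)(=O)c2ccccc21` — 92.8%
compound 3 `CCNC(=O)OCC1=CS(=O)(=O)c2ccccc2C1=O` — 99.3%

In a functional assay on the whole organism for inhibition, with Mus musculus as the target, at a dose of 10 mg/kg (a higher number here means more inhibition at the dose given (going by the name of the read-out), a lower number less inhibition), compound 2 gives 92.8%; the step of a number 6.4 percentage points lower from compound 1 to compound 2 (within the scatter) and the step of a number 6.5 percentage points higher from compound 2 to compound 3 (within the scatter) both lie within the scatter, so all three numbers sit close together. Compound 4 `O=C1C(CBr)=C(CBr)S(=O)(=O)c2ccccc21` carries bromomethyl in place of hydrogen on a double-bonded ring carbon. For the measured compounds named here, no measured step adds a second bromomethyl; the steps that exist only exchange the group already present on the first chain carbon, and none of them moves the read-out beyond the scatter. The expectation for compound 4 is therefore a step of a number 0.8 percentage points lower from compound 2 to compound 4 (within the scatter) that stays within the scatter. Compound 4 is estimated at 92%, range 75% to 99.5%.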

Compound 4, a percentage reported as inhibition, in the whole organism at one dose (the size of the read-out at that dose, not a potency): 53.9%
For compound 4 the middle estimate is 38.1 percentage points above the measured one, and the stated range ends above it.
By their numbers in this assay, from the lowest: compound 4; then compounds 2, 1 and 3 (each within the scatter of the next).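

In this assay, for the compounds shown here, bromomethyl in place of hydrogen on the double-bonded ring carbon next to the ring sulfur gives a number 38.9 percentage points lower from compound 2 to compound 4 (beyond the scatter) and is the first step beyond the scatter. The exchanges on the first chain carbon among compound 1, compound 2 and compound 3 all stayed within the scatter, so this ring carbon is the only place shown where the read-out moves. No measurement here bears on the reason for the drop.

Only hydrogen and bromomethyl are shown at this ring carbon. A plain methyl or an aminomethyl there would test whether the drop belongs to bromomethyl or to any group at this place.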